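This account rests on a few compounds, and the source may have more. Where it says the series, first, only, none or still open, it means among the compounds named here.

Compounds measured in an ADME assay on HeLa cells (Homo sapiens) for cytotoxicity, read by MTT assay, with a stated time of 72 h; on this read-out higher numbers stand for weaker inhibition of growth and lower numbers for stronger inhibition of growth:

Compound 1 `O=C(/C=C\c1cccc([N+](=O)[O-])c1)N1N=C(c2ccncc2)OC1c1c[nH]c2ccccc12` — in this assay compound 1 gives > 30 ug/mL, which is a limit of the assay and not a number.
Compound 2 `O=C(/C=C\c1ccc([N+](=O)[O-])cc1)N1N=C(c2ccncc2)OC1c1c[nH]c2ccccc12` — in this assay compound 2 gives > 30 ug/mL, again a limit of the assay.
Compound 3 `O=C(/C=C\c1cccc(F)c1)N1N=C(c2ccncc2)OC1c1c[nH]c2ccccc12` — in this assay compound 3 gives > 30 ug/mL, also a limit of the assay.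

Compound 2 therefore stands where every measured compound stands: at the limit of > 30 ug/mL in this assay, at which 3 of the 3 values shown sit, with no number of its own to rank it against compound 1 or compound 3. The steps among the measured compounds, a step that the two limits leave unreadable from compound 1 to compound 2, a step that the two limits leave unreadable from compound 1 to compound 3 and a step that the two limits leave unreadable from compound 2 to compound 3, are all unreadable for the same reason, so they show no direction that could be carried forward.

Compound 4 `O=C(/C=C\c1ccc(Cl)cc1Cl)N1N=C(c2ccncc2)OC1c1c[nH]c2ccccc12` differs from compound 2 by 2,4-dichlorophenyl in place of 4-nitrophenyl on a double-bonded chain carbon bound to a double-bonded chain carbon. With three limits and no readable step to lean on, the expectation for compound 4 rests only on the shared core and on the three limits, and it is estimated to sit near the limit again, with an expected step that the limit leaves unreadable from compound 2 to compound 4. Compound 4 is thus estimated at 40 ug/mL, within a range of 15 ug/mL to 100 ug/mL.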

Compound 4, concentration for 50% growth inhibition: 29.3 ug/mL
The estimate for compound 4 lay 1.4-fold (0.14 log units) above the measured number, within the range that was stated.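

In this assay, for the compounds shown here, compound 4 gives 29.3 ug/mL, the only number in the set rather than a limit, so 2,4-dichlorophenyl on a double-bonded chain carbon bound to a double-bonded chain carbon gives this position a value against which the others can be set. The readable floors are an at least 1.0-fold lower number from compound 2 to compound 4 (0.01 log units; that floor lies within the scatter), an at least 1.0-fold lower number from compound 3 to compound 4 (0.01 log units; that floor lies within the scatter) and an at least 1.0-fold lower number from compound 1 to compound 4 (0.01 log units; that floor lies within the scatter), and since each lies within the scatter, none of these changes is shown to alter growth inhibition. The steps among compound 1, compound 2 and compound 3 still cannot be read, as all three remain limits: the limit of > 30 ug/mL in this assay, at which 3 of the 4 values shown sit.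

Going by these compounds, the true size of the three steps to compound 4 stays open. Also open, on these data alone, is whether an amine or a carboxylic acid on the phenyl ring, or a longer chain in place of the ethenyl, would give a step beyond the scatter.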